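The compounds below may be only part of what the source reports. "The series", "measured", "known", "first", "only" and "open" are said of these compounds alone.

Compound 1 `COc1ccc(/C=C2\CNC/C(=C\c3ccc(OC)c(OC)c3)C2=O)cc1OC`: 15100 nM
Compound 2 `CCCN1C/C(=C\c2ccc(OC)c(OC)c2)C(=O)/C(=C/c2ccc(OC)c(OC)c2)C1`: 21000 nM
Compound 3 `CCN1C/C(=C\c2cc(OC)c(OC)c(OC)c2)C(=O)/C(=C/c2cc(OC)c(OC)c(OC)c2)C1`: 12800 nM

These three values come from an ADME assay on L02 cells (Homo sapiens) for cytotoxicity, read by MTT assay, with a stated time of 72 h; on this read-out higher numbers stand for weaker inhibition and lower numbers for stronger inhibition. Compound 3, at 12800 nM, lies within the usual scatter of both compound 1 and compound 2, so the three cannot be told apart on these numbers.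

The next compound is compound 4 `COc1cc(/C=C2\CN(C(=O)C(C)C)C/C(=C\c3cc(OC)c(OC)c(OC)c3)C2=O)cc(OC)c1OC`, which keeps the core of compound 3 but places isopropylcarbonyl in place of ethyl on an amine nitrogen in a ring.

For the measured compounds named here, only one measured step touches that nitrogen: a 1.4-fold higher number from compound 1 to compound 2 (0.14 log units; within the scatter). That step, from hydrogen to propyl, stayed within the scatter. Going by the values given here, it is only a loose guide, as compound 1 and compound 2 also differ from compound 3 elsewhere, and no compound with a carbonyl on that nitrogen has been measured. The data therefore point to no clear change, though with real uncertainty.

The expected change is small: a 1.3-fold lower number from compound 3 to compound 4 (0.11 log units; within the scatter), not beyond the scatter.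

In this assay, the estimate for compound 4 is 10000 nM, with an expected range of 3500 nM to 25000 nM.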

Compound 4, half-maximal inhibitory concentration: 12200 nM
Estimate against measurement, compound 4: 1.2-fold (0.09 log units) below; the measured number falls inside the stated range.
By their numbers in this assay, from the lowest: compounds 4, 3, 1 and 2 (each within the scatter of the next).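

In this assay, for the compounds shown here, replacing ethyl with isopropylcarbonyl gives a 1.0-fold lower number from compound 3 to compound 4 (0.02 log units; within the scatter), so a group bearing a carbonyl on the amine nitrogen in a ring reads the same as a plain ethyl, which the earlier compounds could not show. This step and the earlier one at the same nitrogen, a 1.4-fold higher number from compound 1 to compound 2 (0.14 log units; within the scatter), both stay within the scatter, so among these four compounds the read-out shows no response to the group on this nitrogen, and none of them goes against that. Nothing here offers an explanation for this lack of response.

Still open, from the compounds shown here alone, is whether a carboxylic acid, an amine at the end of a longer chain, or a benzyl group on this nitrogen would fit the same picture. The compounds shown also leave open whether isopropylcarbonyl would behave alike on the core of compound 1.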